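Cyclobutyl Replaces Methyl on the Amide Nitrogen

The compounds below may be only part of what the source reports. "The series", "measured", "known", "first", "only" and "open" are said of these compounds alone.

Compound 1 `CCNC(=O)/C=C1\CCc2ccc(F)cc21` gives 63% in a functional assay on the whole organism with Rattus norvegicus as the target, at a dose of 20 mg/kg by the oral route; a higher number here means more inhibition at the dose given (going by the name of the read-out), a lower number less inhibition. Going by the values given here, compound 2 `CNC(=O)/C=C1\CCc2ccc(F)cc21` gives 38% in this assay, the lower of the two numbers measured so far; the single measured step, a number 25 percentage points lower from compound 1 to compound 2 (beyond the scatter), went against it. Compound 3 `O=C(/C=C1\CCc2ccc(F)cc21)NC1CCC1` awaits measurement, and it differs from compound 2 by cyclobutyl in place of methyl on an amide-type nitrogen. Among the compounds with values here, the only step that bears on this change is a number 25 percentage points lower from compound 1 to compound 2 (beyond the scatter), which points the opposite way to the new substitution, so a rise of comparable size is expected in this assay, a number 25 percentage points higher from compound 2 to compound 3 (beyond the scatter). Compound 3 is estimated at 63%, expected to fall between 42% and 84%.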

Compound 3, a percentage reported as inhibition, in the whole organism at one dose (the size of the read-out at that dose, not a potency): 0%
For compound 3 the middle estimate is 63 percentage points above the measured one, outside the stated range (below it).
By their numbers in this assay, from the lowest: compound 3; then compound 2; then compound 1.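

On the amide-type nitrogen, exchanging methyl for cyclobutyl gives in this assay a number 38 percentage points lower from compound 2 to compound 3 (beyond the scatter), and exchanging ethyl for cyclobutyl gives a number 63 percentage points lower from compound 1 to compound 3 (beyond the scatter). The rise from methyl to ethyl therefore does not extend to cyclobutyl, which stands beneath both groups, so the earlier step does not set a general direction at this position. Nothing available explains this drop. As far as these compounds go, it remains open whether the loss follows the ring itself or would also appear with an open chain. Propyl, isopropyl and cyclopropyl on the same nitrogen are not among the compounds shown.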